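A few compounds are considered here, and "the series" means these few. Any claim that something is new, unique, unknown or untested is made for them only; others in the source may bear on it.

Of the compounds shown here, three built on one shared core have been tested in a functional assay on PC-3 cells (Homo sapiens) for antiproliferative activity, read by MTT assay, with a stated time of 72 h; a lower number here means a stronger inhibitor, a higher number a weaker inhibitor. Compound 1 `CC(C)/C=C/C(=O)Nc1cc2c(N3CCCc4ccccc43)ncnc2cc1O[C@@H]1CCOC1` gives 8510 nM in this test, compound 2 `CN1CCN(C/C=C/C(=O)Nc2cc3c(N4CCc5ccccc54)ncnc3cc2O[C@@H]2CCOC2)CC1` gives 4210 nM in it, and compound 3 `COc1cc2ncnc(N3CCCc4ccccc43)c2cc1NC(=O)/C=C/CN1CCN(C)CC1` gives 6260 nM under the same conditions. The number for compound 3 lies between the other two, nearest to that of compound 1, yet both gaps stay within the usual scatter, so the three values cannot be told apart. Compound 4 `CN1CCN(C/C=C/C(=O)Nc2cc3c(N4CCCc5ccccc54)ncnc3cc2O[C@@H]2CCOC2)CC1` differs from compound 3 only by oxolan-3-yl in place of methyl on an oxygen on an aromatic ring. Within the data shown here, no pair of measured compounds isolates this exact change, so no direction can be read for it. A step of a 1.1-fold lower number from compound 3 to compound 4 (0.06 log units; within the scatter) is expected, staying inside the scatter. For compound 4 the estimated value is 5500 nM, with a range from 2000 nM to 15000 nM.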

Compound 4, half-maximal inhibitory concentration: 9450 nM
Beside the measured number, compound 4's estimate is 1.7-fold (0.24 log units) below it; low and high end bracket the measured number.
By their numbers in this assay, from the lowest: compounds 2, 3, 1 and 4 (each within the scatter of the next, the first and the last beyond it).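

In this assay, oxolan-3-yl in place of methyl on the oxygen gives a 1.5-fold higher number from compound 3 to compound 4 (0.18 log units; within the scatter), so the two groups cannot be told apart at this position. The same holds for (4-methylpiperazin-1-yl)methyl in place of isopropyl, with a 1.1-fold higher number from compound 1 to compound 4 (0.05 log units; within the scatter), while 1,2,3,4-tetrahydroquinolin-1-yl in place of 2,3-dihydro-1H-indol-1-yl gives a 2.2-fold higher number from compound 2 to compound 4 (0.35 log units; beyond the scatter), a modest step beyond the scatter. Nothing measured here explains any of these steps. From the compounds shown here alone, whether a longer chain ending in an amine on that oxygen would move the number stays open.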